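Removing One Methoxy Group from Compound 2

The source may hold more compounds than are shown below. What is called first, only, known or untested is meant among the compounds shown, and "the series" means these compounds.

Compound 2 `COc1cc(-c2cc(/C=C/C(=O)c3ccc(N)cc3)[nH]n2)cc(OC)c1OC` stands lowest of the two numbers measured in a functional assay on T47D cells (Homo sapiens) for cytotoxicity, read by sulforhodamine B assay, with a stated time of 48 h, tested at 10 uM; a higher number here means a weaker effect of the compound at the concentration tested, a lower number a stronger effect: in this assay compound 2 gives -38%, while compound 1 `COc1ccc(-c2cc(/C=C/C(=O)c3ccc(N)cc3)[nH]n2)cc1` gives -1%, a gap beyond the usual scatter. Compound 3 `COc1ccc(-c2cc(/C=C/C(=O)c3ccc(N)cc3)[nH]n2)cc1OC` has not yet been measured in this assay. It differs from compound 2 in one place: hydrogen in place of methoxy on an aromatic carbon. Among the compounds with values here, no step between two measured compounds matches this change, so its size can only be judged from what compound 1 and compound 2 show. Compound 3 carries one methoxy fewer than compound 2 and one more than compound 1, and its value is expected to fall between those two. The estimated step from compound 2 to compound 3 in this assay is a number 20 percentage points higher from compound 2 to compound 3 (beyond the scatter), upward toward a weaker effect. For compound 3 the expected value in this assay is -18%, within a range from -40% to 5%.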

Compound 3, a percentage reported as activity, at one concentration (the size of the read-out at that concentration, not a potency): 28%
Beside the measured number, compound 3's estimate is 46 percentage points below it, outside the stated range (above it).
By their numbers in this assay, from the lowest: compound 2; then compound 1; then compound 3.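

Removing the methoxy ortho to a methoxy group and meta to a large group gives, in this assay, a number 66 percentage points higher from compound 2 to compound 3 (beyond the scatter), so the aromatic carbon that carries it strongly affects the read-out in the setting of compound 2. The step on the same ring in the other direction, methoxy in place of hydrogen, gives a number 29 percentage points higher from compound 1 to compound 3 (beyond the scatter), also toward a weaker effect, so among these compounds the read-out does not follow the number of methoxy groups alone. Nothing available here accounts for either step.

On these data alone, what remains open is whether the methoxy group itself matters at this position, or whether a hydroxyl group, a chlorine atom or an ethoxy group there would behave in the same way. The compounds shown also do not tell whether an amine or a longer alkoxy chain would be tolerated on this carbon.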